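This account rests on a few compounds, and the source may have more. Where it says the series, first, only, none or still open, it means among the compounds named here.

Measured so far in a toxicity assay on the whole organism (J774 cells) for cytotoxicity, with Mus musculus as the target, read by MTT assay, with a stated time of 24 h, tested at 10 uM; on this read-out lower numbers stand for a stronger effect and higher numbers for a weaker effect at the one concentration tested:
Compound 1, `CCCCCCCCCO[C@@H]1[C@@H](N)[C@@H](OC[C@H](O)CN=[N+]=[N-])O[C@H](CN)[C@H]1OCCCCCCCCC`, gives 62.2%.
Compound 2, `NC[C@H]1O[C@H](O[C@H]2[C@H](OCCCc3ccc4ccccc4c3)[C@@H](O)[C@H](N)C[C@@H]2N)[C@H](N)[C@@H](OCCCc2ccc3ccccc3c2)[C@@H]1O`, gives 91.1%.

Among the measured compounds shown here, only these two numbers exist in this assay, and no step between a matched pair has been worked out for them. Compound 1 stands lowest of the two; compound 2, its nearest neighbour, sits higher by a gap that lies beyond the usual scatter of this read-out, so the two values do differ. Beyond that, the two compounds differ in several places at once, and their values are reported here only as what they are.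

The next compound to be measured is compound 3, `CCCCCCCCCO[C@@H]1[C@@H](N)[C@@H](O[C@H]2[C@H](O)[C@@H](O)[C@H](N)C[C@@H]2N)O[C@H](CN)[C@H]1OCCCCCCCCC`. It keeps the core and both nonyl chains of compound 1 and changes one place: 4,6-diamino-2,3-dihydroxycyclohexyl in place of 3-azido-2-hydroxypropyl on an oxygen on a saturated carbon. The entering ring also occurs in compound 2, and compound 2 gives 91.1% in this assay. On that basis a step in the upward direction is expected, of moderate size, a number 12.8 percentage points higher from compound 1 to compound 3 (beyond the scatter), and it may well fall within the scatter. Compound 3 is therefore estimated at 75%, with a range from 55% to 95%.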

Compound 3, a percentage reported as activity, at one concentration (the size of the read-out at that concentration, not a potency): 82.7%
For compound 3 the middle estimate is 7.7 percentage points below the measured one; low and high end bracket the measured number.
By their numbers in this assay, from the lowest: compound 1; then compounds 3 and 2 (each within the scatter of the next).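

In this assay, with the core and both nonyl chains held constant, replacing 3-azido-2-hydroxypropyl with 4,6-diamino-2,3-dihydroxycyclohexyl on an oxygen on a saturated carbon gives a number 20.5 percentage points higher from compound 1 to compound 3 (beyond the scatter) and so corresponds to a weaker effect at the one concentration tested. Among the compounds shown here, compound 1 and compound 2 differ in several places at once, so this matched step is the first to show that a change at this position alone can move the read-out beyond the usual scatter. Nothing available explains the size or direction of this step.

The compounds shown leave open which part of the exchange carries the step, since the ring, its two amines and its two hydroxyls enter together while the azide leaves, and a plain cyclohexyl or a 3-amino-2-hydroxypropyl group on the same oxygen would separate these parts. For the compounds shown here, it also remains open whether the same exchange gives a similar step with a chain other than nonyl on the core, such as a longer chain, because this single pair covers only one chain length.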